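The compounds below may be only part of what the source reports. "The series", "measured", "known", "first", "only" and "open" are said of these compounds alone.

Measured in a functional assay on DU-145 cells (Homo sapiens) for inhibition, read by trypan blue exclusion, with a stated time of 96 h; a lower number here means a stronger inhibitor of growth, a higher number a weaker inhibitor of growth:
- compound 1 `Cc1ccc(/C=C(\C(=O)c2ccc(Br)cc2)S(=O)(=O)Cc2ccc(F)cc2)s1`: 1000 nM
- compound 2 `O=C(/C(=C\c1cc([N+](=O)[O-])ccc1F)S(=O)(=O)Cc1ccc(F)cc1)c1ccc(Br)cc1`: > 100000 nM

Compound 2 has no number, only a limit of the assay: > 100000 nM.

Compound 3 `CN(C)c1ccc(/C=C(\C(=O)c2ccc(Br)cc2)S(=O)(=O)Cc2ccc(F)cc2)cc1` differs from it as follows: 4-(dimethylamino)phenyl in place of 2-fluoro-5-nitrophenyl on a double-bonded chain carbon bound to a double-bonded chain carbon. Going by the values given here, the only measured step at this place, an at least 100-fold higher number from compound 1 to compound 2 (2.00 log units; beyond the scatter), was large and beyond the scatter, and it brought in the 2-fluoro-5-nitrophenyl that compound 3 gives up. A large step to a lower number is therefore expected in this assay, back toward compound 1 at 1000 nM. The expected step is an at least 50-fold lower number from compound 2 to compound 3 (1.69 log units; beyond the scatter). For compound 3 the estimated value is 2000 nM, with an expected range of 200 nM to 20000 nM.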

Compound 3, concentration for 50% growth inhibition: 50000 nM
Estimate against measurement, compound 3: 25-fold (1.40 log units) below; the measured number lies above the stated range.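

In this assay, 4-(dimethylamino)phenyl at this place does not bring back the growth inhibition of compound 1, with a 50-fold higher number from compound 1 to compound 3 (1.70 log units; beyond the scatter). Measured against compound 2, the change gives an at least 2.0-fold lower number from compound 2 to compound 3 (0.30 log units; that floor lies within the scatter), so any real gain remains unproven and its true size unknown. Compound 2 has only a limit of the assay, not a number: the limit of > 100000 nM in this assay, at which 1 of the 3 values shown sits.

The compounds shown leave open whether the stronger inhibition by compound 1 depends on the thiophene ring or on its methyl group. A plain thiophen-2-yl or a 4-methylphenyl at this place would separate the two.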